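Swapping the benzothiazole amide for a chlorophenyl amide

A few compounds are considered here, and "the series" means these few. Any claim that something is new, unique, unknown or untested is made for them only; others in the source may bear on it.

Measured compounds:
compound 1 `O=C(CCCCCCNC(=O)C(O)(O)C(F)(F)F)Nc1nc2ccccc2s1`, 2370 nM
compound 2 `O=C(CCCCCCNC(=O)C(O)(O)C(F)(F)F)Nc1nc2ccc(Br)cc2s1`, 10300 nM
compound 3 `NC(=O)C(=O)NCCCCCC(=O)Nc1ccccc1`, a limit, > 100000 nM

In a functional assay on HCT-116 cells (Homo sapiens) for inhibition, read by colorimetric assay, with a stated time of 3 days (on this read-out higher numbers stand for weaker inhibition and lower numbers for stronger inhibition), compound 1 stands lowest of the two numbers shown, with compound 2 nearest at a 4.3-fold higher number from compound 1 to compound 2 (0.64 log units; beyond the scatter). For compound 3 this assay reports only a limit, > 100000 nM, at which one of the three values sits (the limit of > 100000 nM in this assay, at which 1 of the 3 values shown sits). Compound 4 `O=C(CCCCCCNC(=O)C(O)(O)C(F)(F)F)Nc1ccc(Cl)cc1` differs from compound 1 by 4-chlorophenyl in place of 1,3-benzothiazol-2-yl on an amide-type nitrogen. Going by the values given here, no measured step matches this change; the step from compound 1 to compound 2, a halogen placed on the aromatic ring, weakened inhibition modestly, and compound 3, which also carries a phenyl amide, gave only a limit. Compound 4 is therefore expected to be weaker, with the estimated step of a 6.3-fold higher number from compound 1 to compound 4 (0.80 log units; beyond the scatter), giving an estimate of 15000 nM within 4000 nM to 80000 nM.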

Compound 4, half-maximal inhibitory concentration: 4230 nM
The estimate for compound 4 lay 3.5-fold (0.55 log units) above the measured number; low and high end bracket the measured number.
By their numbers in this assay, from the lowest: compounds 1 and 4 (each within the scatter of the next); then compound 2. At a limit, above all of these: compound 3.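

In this assay, 4-chlorophenyl in place of 1,3-benzothiazol-2-yl on the amide-type nitrogen gives a 1.8-fold higher number from compound 1 to compound 4 (0.25 log units; within the scatter). Going by these compounds alone, compounds 1 and 2 both keep the 1,3-benzothiazol-2-yl, so only this step shows that the five-membered aromatic ring with its two hetero atoms can leave without a change beyond the scatter. Nothing measured here gives a cause for this step. Still open, on these data alone, is how a plain phenyl, or a phenyl carrying an amine or a carboxylic acid, would read at this nitrogen. Also open, as far as these compounds go, is whether a longer chain would keep compound 4 at this level.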